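Aryl swap on sulfur: compound 3 to compound 4

The source may hold more compounds than are shown below. What is called first, only, known or untested is meant among the compounds shown, and "the series" means these compounds.

In a functional assay on A-375 cells (Homo sapiens) for inhibition, read by CCK-8 assay, with a stated time of 72 h, tested at 2 uM (on this read-out lower numbers stand for less inhibition of growth and higher numbers for more inhibition of growth at the one concentration tested), compound 1 `Cc1cc(C)cc(SCc2ccc(/C=C/C(=O)Nc3ccccc3N)cc2)c1` gives 8.78% and compound 2 `CCc1ccc(SCc2ccc(/C=C/C(=O)Nc3ccccc3N)cc2)cc1` gives 5.27% while compound 3 `COc1ccc(SCc2ccc(C(=O)Nc3ccccc3N)cc2)cc1` gives 10.2% and so stands within the scatter of both. No real separation exists among these three values.

The next compound to be read is compound 4 `Nc1ccccc1NC(=O)c1ccc(CSc2cccc(F)c2)cc1`. It keeps the core of compound 3 and differs by 3-fluorophenyl in place of 4-methoxyphenyl on a sulfur which reads as 3-fluorophenyl in place of 4-methoxyphenyl on a sulfur.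

Going by the values given here, only one measured step bears on a swap at this sulfur. It is a number 3.5 percentage points lower from compound 1 to compound 2 (within the scatter) for 4-ethylphenyl in place of 3,5-dimethylphenyl on a sulfur, and it sits on a core that differs from that of compound 3. Among the compounds with values here, no measured pair contains 3-fluorophenyl, so the direction of the change stays open. On that single small step, no step beyond the scatter is expected in this assay for this swap.

The estimated step is a number 1.2 percentage points lower from compound 3 to compound 4 (within the scatter) and no direction is claimed for it. Within the data shown here, only three compounds are measured, and the range is kept wide. For compound 4 the estimate is 9% with 2% to 20% as the expected range.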

Compound 4, percent growth inhibition at one concentration: 37.7%
Beside the measured number, compound 4's estimate is 28.7 percentage points below it; the measured number lies above the stated range.
By their numbers in this assay, from the lowest: compounds 2, 1 and 3 (each within the scatter of the next); then compound 4.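

In this assay, going by these compounds alone, 3-fluorophenyl in place of 4-methoxyphenyl on a sulfur gives a number 27.5 percentage points higher from compound 3 to compound 4 (beyond the scatter) and is the first step at this position to lie beyond the scatter. The only other step at this sulfur, a number 3.5 percentage points lower from compound 1 to compound 2 (within the scatter) on a different core, stays within the scatter, so the sensitivity to the aryl group is shown on the core of compound 3 alone and cannot be extended to the core of compound 1. No measurement at hand accounts for the gain, and this single swap cannot separate the arrival of 3-fluorophenyl from the departure of 4-methoxyphenyl.

From the compounds shown here alone, whether the gain belongs to the fluorine itself remains open: a plain phenyl on the sulfur, or a phenyl carrying chlorine, a nitrile or an amine, would help to settle that on the core of compound 3. Also open, going by these compounds, is whether 3-fluorophenyl on the sulfur would give a similar step on the core of compound 1, and how compound 4 would read at other concentrations.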